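A few compounds are considered here, and "the series" means these few. Any claim that something is new, unique, unknown or untested is made for them only; others in the source may bear on it.

Measured compounds:
compound 1, `CNS(=O)(=O)c1ccc(Nc2ncc3c(n2)N(C)C(c2ccccc2C)C(=O)N3C)cc1`: 104 nM in an assay on Sf9 cells for inhibition of serine/threonine-protein kinase 4 (Homo sapiens), read by luminescence and ADP-Glo, with a stated time of 1 h, in the presence of a further agent that is not named here; a higher number here means a weaker inhibitor, a lower number a stronger inhibitor
compound 2, `Cc1ccccc1C1C(=O)N(C)c2cnc(Nc3ccc(S(=O)(=O)NC4CC4)cc3)nc2N1C`: 53 nM

Among the compounds with values here, compound 2 has the lowest of the two numbers; the only measured step, a 2.0-fold lower number from compound 1 to compound 2 (0.29 log units; within the scatter), lies within the scatter, so the two values cannot be ordered. Compound 3, `Cc1ccccc1C1C(=O)N(C)c2cnc(Nc3ccc(S(=O)(=O)NCC4CC4)cc3)nc2N1C`, differs from compound 2 by cyclopropylmethyl in place of cyclopropyl on a sulfonamide nitrogen. Within the data shown here, the one step that bears on this change, a 2.0-fold lower number from compound 1 to compound 2 (0.29 log units; within the scatter), is also a change on the sulfonamide nitrogen and stayed within the scatter, so no step beyond the scatter is expected in this assay for compound 3. Compound 3 is therefore estimated at 50 nM, range 20 nM to 130 nM, a step of a 1.1-fold lower number from compound 2 to compound 3 (0.03 log units; within the scatter).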

Compound 3, half-maximal inhibitory concentration: 60 nM
Compound 3: middle estimate off by 1.2-fold (0.08 log units), on the low side, within the range that was stated.
By their numbers in this assay, from the lowest: compounds 2, 3 and 1 (each within the scatter of the next).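

Cyclopropylmethyl in place of cyclopropyl on the sulfonamide nitrogen gives a 1.1-fold higher number from compound 2 to compound 3 (0.05 log units; within the scatter) in this assay and so adds a second step within the scatter at this position. Measured against the methyl-bearing compound, the same group gives a 1.7-fold lower number from compound 1 to compound 3 (0.24 log units; within the scatter) and so methyl, cyclopropyl and cyclopropylmethyl on this nitrogen cannot be ordered here. No supporting measurement explains this flat result.

Still open, on these data alone, is whether a longer chain, an amine or a carboxylic acid on this nitrogen would produce a step beyond the scatter.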